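The compounds below may be only part of what the source reports. "The series", "measured", "known", "first", "only" and "open" are said of these compounds alone.

Compound 2 `COc1ccc(-c2c3ccc4ccccc4c3nc3c2c(C)nc2c4ccccc4ccc32)cc1` gives 82.3 ug/mL in a functional assay, read by spectrophotometry, with a stated time of 15 min; on this read-out lower numbers stand for stronger inhibition and higher numbers for weaker inhibition. Within the data shown here, the only other number in this assay comes from compound 1 `Cc1nc2c3ccccc3ccc2c2nc3c(ccc4ccccc43)c(-c3cccnc3)c12`, which gives 63.6 ug/mL. On these two numbers compound 2 cannot be set apart from compound 1, since a 1.3-fold higher number from compound 1 to compound 2 (0.11 log units; within the scatter) leaves the pair indistinguishable.

Compound 3 `Cc1nc2c3ccccc3ccc2c2nc3c(ccc4ccccc43)c(-c3ccccc3N)c12` differs from compound 2 at the same position that changes between compounds 1 and 2: 2-aminophenyl in place of 4-methoxyphenyl on an aromatic carbon.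

Among the measured compounds shown here, no measured step places a 2-aminophenyl, or any group carrying a hydrogen-bond donor, at this position, so the one measured step is the only guide. That step, a 1.3-fold higher number from compound 1 to compound 2 (0.11 log units; within the scatter), shows that exchanging the aryl group here between a pyridin-3-yl and a 4-methoxyphenyl leaves the number within the scatter. By analogy the step to compound 3 is expected to be small, with no direction beyond the scatter, so a 1.1-fold lower number from compound 2 to compound 3 (0.04 log units; within the scatter) is the expected step.

For the measured compounds named here, the estimate for compound 3 in this assay is therefore 75 ug/mL, with an expected range from 35 ug/mL to 160 ug/mL, the breadth reflecting that the 2-aminophenyl has no measured precedent.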

Compound 3, half-maximal inhibitory concentration: 45.6 ug/mL
Beside the measured number, compound 3's estimate is 1.6-fold (0.22 log units) above it; low and high end bracket the measured number.
By their numbers in this assay, from the lowest: compounds 3, 1 and 2 (each within the scatter of the next).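

In this assay, among these compounds, the position opposite the ring nitrogen accepts a 2-aminophenyl, the one group in this set counted with a hydrogen-bond donor, without a separation from the 4-methoxyphenyl (a 1.8-fold lower number from compound 2 to compound 3 (0.26 log units; within the scatter)) or from the pyridin-3-yl (a 1.4-fold lower number from compound 1 to compound 3 (0.14 log units; within the scatter)). Among the compounds shown here, each of the three compounds now has a step to both others printed within the scatter, so the series cannot rank these three aryl groups, and no compound here can be called the strongest or the weakest. Nothing available gives a measured property or a reason that bears on this result.

All three groups shown at this position are built on a single six-membered aromatic ring, so it remains open whether a group of another kind, such as a morpholine, a carboxylic acid or a longer alkyl chain, would give a step beyond the scatter. Also open, going by these compounds, are the effect of moving the amine around the phenyl ring, as in 4-aminophenyl, and the effect of replacing the methyl group on the shared core with an ethyl group.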